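The source may report more compounds than this note shows. Statements on the series, on what has been measured and on what is new or still open speak of the compounds shown alone.

Measured in a functional assay on T47D cells (Homo sapiens) for inhibition, read by CCK-8 assay, with a stated time of 72 h, tested at 1 uM; a higher number here means more inhibition of growth at the concentration tested, a lower number less inhibition of growth:
compound 1 `CN(C)C(=O)c1cc2cnc(Nc3ccc(NC(=O)C4(C(=O)Nc5cccc(C(F)(F)F)c5)CC4)cc3)nc2n1C1CCCC1` gives 9.7%
compound 2 `COc1cccc(NC(=O)C2(C(=O)Nc3ccc(Nc4ncc5cc(C(=O)N(C)C)n(C6CCCC6)c5n4)cc3)CC2)c1` gives 56.3%
compound 3 `CN(C)C(=O)c1cc2cnc(Nc3ccc(NC(=O)C4(C(=O)Nc5cccc(Br)c5)CC4)cc3)nc2n1C1CCCC1` gives 29.1%

Compound 3 is second highest of the three numbers. Its nearest neighbour is compound 1, with a number 19.4 percentage points higher from compound 1 to compound 3 (beyond the scatter) as the gap, and its furthest is compound 2, with a number 27.2 percentage points lower from compound 2 to compound 3 (beyond the scatter) as the gap. Both gaps lie beyond the scatter.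

The next structure is compound 4 `CN(C)C(=O)c1cc2cnc(Nc3ccc(NC(=O)C4(C(=O)Nc5ccccc5)CC4)cc3)nc2n1C1CCCC1` and the change is hydrogen in place of bromo on an aromatic carbon in short, hydrogen in place of bromo on an aromatic carbon, meta to a large group. All three measured steps are exchanges at this same place, which makes them the relevant evidence: a number 46.6 percentage points higher from compound 1 to compound 2 (beyond the scatter) is large, while a number 19.4 percentage points higher from compound 1 to compound 3 (beyond the scatter) and a number 27.2 percentage points lower from compound 2 to compound 3 (beyond the scatter) are modest. None of them has hydrogen on either side, so the data fix no direction for removing bromo. Exchanges at this place have moved the number both up and down from compound 3, so a modest move either way remains possible.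

The expected outcome is no step beyond the scatter, with the estimated step of a number 6.9 percentage points higher from compound 3 to compound 4 (within the scatter) as the central guess. For compound 4 the estimated value is 36% with an expected range of 15% to 60% as its bounds.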

Compound 4, percent growth inhibition at one concentration: 52.8%
Estimate against measurement, compound 4: 16.8 percentage points below; low and high end bracket the measured number.
By their numbers in this assay, from the lowest: compound 1; then compound 3; then compounds 4 and 2 (each within the scatter of the next).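

Going by these compounds alone, with hydrogen at this place, the series gains an unsubstituted reference that the earlier compounds lacked: in this assay, replacing bromo with hydrogen gives a number 23.7 percentage points higher from compound 3 to compound 4 (beyond the scatter), and replacing trifluoromethyl with hydrogen gives a number 43.1 percentage points higher from compound 1 to compound 4 (beyond the scatter), so both substituents go with less growth inhibition than the plain phenyl. Methoxy does not follow this pattern, as replacing it with hydrogen gives a number 3.5 percentage points lower from compound 2 to compound 4 (within the scatter), a step that does not separate the two groups. The large gap between the trifluoromethyl and methoxy compounds therefore reads as a loss seen with trifluoromethyl rather than a gain from methoxy, and the same reading holds to a lesser extent for bromo.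

Nothing available bears on the reason for these differences at this place. On these data alone, it remains open whether a small group such as fluoro, or a different kind of group such as an amine or a carboxylic acid, would stay level with hydrogen and methoxy or fall toward bromo and trifluoromethyl, and whether the same order would hold at concentrations other than the single one tested.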